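Shortening the Amide Chain Toward Acetamide

A few compounds are considered here, and "the series" means these few. Any claim that something is new, unique, unknown or untested is made for them only; others in the source may bear on it.

compound 1, `CCCC(=O)NCC1CCCc2ccc(OC)cc21`: 0.45 nM
compound 2, `CCC(=O)NCC1CCCc2ccc(OC)cc21`: 0.53 nM; > 1000 nM; 0.45 nM (3 entries)

In an assay for binding affinity to melatonin receptor type 1B (Gallus gallus), read by radioligand binding (on this read-out lower numbers stand for stronger inhibition and higher numbers for weaker inhibition), compound 1 gives 0.45 nM, the only single number shown. Compound 2 has several entries, (the several entries of compound 2 in this assay, 0.53 nM; > 1000 nM; 0.45 nM (3 entries)), and one of them is a limit of the assay rather than a number. Compound 3, `COc1ccc2c(c1)C(CNC(C)=O)CCC2`, is not yet measured. It differs from compound 1 by hydrogen in place of ethyl on a saturated chain carbon bound to a carbonyl carbon. For the measured compounds named here, with no measured step of this kind, a small loss beyond the scatter is expected from compound 1 to compound 3, a 3.3-fold higher number from compound 1 to compound 3 (0.52 log units; beyond the scatter). Compound 3 is estimated at 1.5 nM, within 0.3 nM to 8 nM.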

Compound 3, inhibition constant: 4 nM
Beside the measured number, compound 3's estimate is 2.7-fold (0.43 log units) below it; the range from low to high includes it.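

In this assay, hydrogen in place of ethyl on the saturated chain carbon bound to the carbonyl carbon gives an 8.9-fold higher number from compound 1 to compound 3 (0.95 log units; beyond the scatter). This position is therefore sensitive to the size of the chain, though the loss is modest. Compound 2 cannot show where along the shortening the loss sets in, since its entries disagree and one is a limit of the assay: the several entries of compound 2 in this assay, 0.53 nM; > 1000 nM; 0.45 nM (3 entries)

Going by these compounds, whether a longer chain such as butyl, or a ring such as cyclopropyl, at this place would lower the number or raise it stays open.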